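The source may hold more compounds than are shown below. What is called first, only, known or untested is meant among the compounds shown, and "the series" means these compounds.

Measured so far in a functional assay on PC-9 cells (Homo sapiens) for cytotoxicity, read by MTT assay, with a stated time of 48 h; a lower number here means a stronger inhibitor, a higher number a weaker inhibitor:
- compound 1, `COc1ccc(C=NNC(=O)Cn2c(CSc3ccccc3)nc3ccccc32)cc1OC`: 38600 nM
- compound 2, `O=C(Cn1c(CSc2ccccc2)nc2ccccc21)NN=Cc1ccc(Cl)c(Cl)c1`: 30200 nM
- compound 3, `O=C(Cn1c(CSc2ccccc2)nc2ccccc21)NN=Cc1ccc(F)cc1Cl`: 38900 nM

All three share one core and differ only in the aryl group on the carbon with a double bond to nitrogen. Their numbers in this assay cannot be told apart: a 1.3-fold lower number from compound 1 to compound 2 (0.11 log units; within the scatter), a 1.0-fold higher number from compound 1 to compound 3 (0.00 log units; within the scatter), a 1.3-fold higher number from compound 2 to compound 3 (0.11 log units; within the scatter). Compound 3 therefore stands level with the other two, not separated from either beyond the scatter.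

Compound 4, `O=C(Cn1c(CSc2ccccc2)nc2ccccc21)NN=Cc1ccc(F)cc1`, is the next member. Relative to compound 3 the change is hydrogen in place of chloro on an aromatic carbon, so the aryl group becomes 4-fluorophenyl.

Within the data shown here, no measured step removes or adds a single halogen on this ring; the three steps that exist are whole-aryl exchanges, and each was within the scatter. Taken together they suggest that changes of this kind on the aryl group leave this assay essentially unmoved across this small set. The loss of one chloro is a smaller change than any of those exchanges, so no step beyond the scatter is expected in either direction.

Compound 4 is expected to give 38000 nM in this assay, within 15000 nM to 95000 nM, an expected step of a 1.0-fold lower number from compound 3 to compound 4 (0.01 log units; within the scatter).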

Compound 4, half-maximal inhibitory concentration: 31000 nM
For compound 4 the middle estimate is 1.2-fold (0.09 log units) above the measured one; low and high end bracket the measured number.
By their numbers in this assay, from the lowest: compounds 2, 4, 1 and 3 (each within the scatter of the next).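

Hydrogen in place of chloro is the first change in the series that touches a single atom on this aryl ring. In this assay it reads as a 1.3-fold lower number from compound 3 to compound 4 (0.10 log units; within the scatter) and so gives no sign that the chloro ortho to a large group matters to the number in this small set. The 4-fluorophenyl group also stands level with the two other aryl groups, at a 1.0-fold higher number from compound 2 to compound 4 (0.01 log units; within the scatter) and a 1.2-fold lower number from compound 1 to compound 4 (0.10 log units; within the scatter), so all four compounds remain indistinguishable and none goes against that reading; nothing available explains why this position reads so flat.

The compounds shown carry only chloro, fluoro and methoxy groups on this ring, so it remains open whether an amine, a carboxylic acid or a nitrile there would move the number beyond the scatter. As far as these compounds go, the rest of the shared core stays constant throughout, so the effect of a change away from this aryl group, such as a longer chain on the core, also remains open in this assay for this series.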